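Amide substituent change from compound 2 to compound 3

This account rests on a few compounds, and the source may have more. Where it says the series, first, only, none or still open, it means among the compounds named here.

In an ADME assay on MT4 cells (Homo sapiens) for cytotoxicity, read by MTT assay (on this read-out higher numbers stand for lower toxicity in this test and lower numbers for higher toxicity in this test), compound 1 `Cc1cc(C)cc(S(=O)(=O)c2c(C(=O)NCc3ccccc3)[nH]c3ccc(Cl)cc23)c1` gives 38000 nM as a measured number. Compound 2 `Cc1cc(C)cc(S(=O)(=O)c2c(C(=O)NCc3ccco3)[nH]c3ccc(Cl)cc23)c1` reads > 56400 nM and that is a limit, not a number. For the measured compounds named here, compound 3 `Cc1cc(C)cc(S(=O)(=O)c2c(C(=O)NC(C)c3cccs3)[nH]c3ccc(Cl)cc23)c1` keeps the shared core and carries 1-(thiophen-2-yl)ethyl in place of (furan-2-yl)methyl on an amide-type nitrogen as its only difference from compound 2. Going by the values given here, the one measured step that bears on this is an at least 1.4-fold higher number from compound 1 to compound 2 (0.17 log units; that floor lies within the scatter) with furan-2-yl in place of phenyl, and it gives only a floor. Among the compounds with values here, no measured step covers the 1-(thiophen-2-yl)ethyl group itself. A modest move toward a lower number is therefore expected, and an at least 1.6-fold lower number from compound 2 to compound 3 (0.20 log units; that floor lies within the scatter) is the estimated step in this assay for this change. For compound 3 the estimate is 35000 nM with an expected range from 12000 nM to 60000 nM on this read-out.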

Compound 3, half-maximal cytotoxic concentration: 32300 nM
Compound 3: the middle estimate sits 1.1-fold (0.03 log units) above what was measured; low and high end bracket the measured number.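

Compound 2 gives a limit and not a number in this assay: the limit of > 56400 nM in this assay, at which 1 of the 3 values shown sits.

On these data alone, the change on the amide-type nitrogen gives an at least 1.7-fold lower number from compound 2 to compound 3 (0.24 log units; that floor lies within the scatter), so only a floor is known and the true size of this step stays open. The 1-(thiophen-2-yl)ethyl group supplies the only measured number shown for a five-membered aromatic ring at this position, and the comparison with benzyl gives a 1.2-fold lower number from compound 1 to compound 3 (0.07 log units; within the scatter), so these two groups cannot be told apart in this assay.

The compounds shown hold neither (thiophen-2-yl)methyl nor 1-(furan-2-yl)ethyl, so the exchange of oxygen for sulfur and the extra methyl on the chain carbon cannot be separated. As far as these compounds go, how a longer chain carrying the ring, or a carboxylic acid on that ring, would read in this assay also stays open.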